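From compound 1 to compound 4: one group exchanged

The source may hold more compounds than are shown below. What is called first, only, known or untested is meant among the compounds shown, and "the series" means these compounds.

Measured so far in an ADME assay on cells (Hepatocyte, Mus musculus) for metabolic stability, with a stated time of 30 min; on this read-out higher numbers stand for a more stable compound and lower numbers for a less stable compound
compound 1 `Cc1ccc(C(=O)OC2CCC(CN3CCN(c4cc(=O)c5cc(C(F)(F)F)cc([N+](=O)[O-])c5s4)CC3)CC2)cc1` gives 18%
compound 2 `O=C(OC1CCC(CN2CCN(c3cc(=O)c4cc(C(F)(F)F)cc([N+](=O)[O-])c4s3)CC2)CC1)c1ccc(C(F)(F)F)cc1` gives 28.8%
compound 3 `Nc1cc(C(F)(F)F)cc2c(=O)cc(N3CCN(CC4CCCCC4)CC3)sc12` gives 69.4%

Compound 1 has the lowest of these three numbers. Compound 4 `CC(=O)NC1CCC(CN2CCN(c3cc(=O)c4cc(C(F)(F)F)cc([N+](=O)[O-])c4s3)CC2)CC1` has not yet been measured. It carries acetamido in place of ((4-methylphenyl)carbonyl)oxy on a saturated ring carbon of compound 1, and the counted change is acetamido in place of ((4-methylphenyl)carbonyl)oxy on a saturated ring carbon here. Among the measured compounds shown here, the only measured step is a number 10.8 percentage points higher from compound 1 to compound 2 (beyond the scatter) and it is modest. It sits at a different place, on an aromatic carbon, so it guides only loosely. Compound 3 carries neither group and gives 69.4% but its core differs too. A clear rise in this assay is therefore expected, though its size is uncertain. The expected move is a number 22 percentage points higher from compound 1 to compound 4 (beyond the scatter) by this estimate. For compound 4 the estimated value is 40% with 20% to 65% as the expected range.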

Compound 4, percent of the compound remaining: 94.9%
Estimate against measurement, compound 4: 54.9 percentage points below; measured number above the stated range.
By their numbers in this assay, from the lowest: compound 1; then compound 2; then compound 3; then compound 4.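

With acetamido in place of ((4-methylphenyl)carbonyl)oxy on the saturated ring carbon, this assay shows a number 76.9 percentage points higher from compound 1 to compound 4 (beyond the scatter), so the group at this position can move the read-out by a large amount. The exchange changes several things at once: an aromatic ring leaves, the group becomes smaller, and a hydrogen-bond donor enters, so the step cannot be assigned to any one of them. Nothing available here explains the rise.

As far as these compounds go, it remains open whether a plain amine or a longer acyl chain, such as butanoylamino, on this ring carbon would give a similarly high number.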